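Methoxy added to the phenyl ring of compound 2

The source may hold more compounds than are shown below. What is called first, only, known or untested is meant among the compounds shown, and "the series" means these compounds.

Measured compounds:
compound 1 `COc1ccc(-c2cn([C@H]3C[C@H](CO)N(C)O3)nn2)cc1` gives 8010 nM
compound 2 `CN1O[C@H](n2cc(-c3ccccc3)nn2)C[C@@H]1CO` gives 8760 nM

Of the compounds shown here, two have been measured in a functional assay on 8305C cells (Homo sapiens) for cytotoxicity, read by MTT assay, with a stated time of 24 h; on this read-out lower numbers stand for stronger inhibition and higher numbers for weaker inhibition. Compound 2 has the highest of the two numbers, but the values of compound 2 and compound 1 differ by an amount that lies within the usual scatter of repeated measurements, so the two compounds cannot be told apart on this read-out.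

Compound 3 `COc1ccc(-c2cn([C@@H]3C[C@H](CO)N(C)O3)nn2)cc1` has not yet been measured in this assay. It is derived from compound 2 by a single change: methoxy in place of hydrogen on an aromatic carbon. Compound 1 also carries a methoxy group on its phenyl ring, and its value in this assay sits close to that of compound 2, although compound 1 and compound 3 differ in their spatial arrangement at one stereocentre. Among the compounds with values here, with no measured step of this kind available, the step from compound 2 to compound 3 is expected to stay within the scatter, with no clear direction, giving a 1.0-fold lower number from compound 2 to compound 3 (0.01 log units; within the scatter). On that basis, compound 3 is estimated at 8500 nM in this assay, within a range of 4000 nM to 18000 nM.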

Compound 3, half-maximal inhibitory concentration: 7180 nM
The estimate for compound 3 lay 1.2-fold (0.07 log units) above the measured number, and the stated range covers the measured number.
By their numbers in this assay, from the lowest: compounds 3, 1 and 2 (each within the scatter of the next).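

In this assay, methoxy in place of hydrogen on the aromatic carbon para to a large group gives a 1.2-fold lower number from compound 2 to compound 3 (0.09 log units; within the scatter), so at this position the change cannot be told apart from repeat measurement. Compounds 1 and 2 differ in two places at once, so neither change could be judged alone; compound 3 now gives each change its own one-place comparison. The second comparison gives a 1.1-fold lower number from compound 1 to compound 3 (0.05 log units; within the scatter), so on this read-out the two drawn configurations at the saturated ring carbon also cannot be separated, and this pair speaks to that stereocentre alone for one reason: the fact that compounds 1 and 3 differ only in the configuration as drawn

The compounds shown leave open whether a different group on the same aromatic carbon, such as an amine, a carboxylic acid or a longer chain in place of methoxy, would move the number beyond the scatter. They also leave open whether the configuration at the stereocentre would matter on a phenyl ring without methoxy, since only the methoxy-bearing pair offers that comparison.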